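This account rests on a few compounds, and the source may have more. Where it says the series, first, only, none or still open, it means among the compounds named here.

In a functional assay on MT4 cells (Homo sapiens) for inhibition (a lower number here means a stronger inhibitor, a higher number a weaker inhibitor), three compounds sharing one core have been tested. Compound 1 `C=C1[C@H](n2ccc(=O)[nH]c2=O)O[C@H](CO)[C@H]1O` reads > 500000 nM, which is a limit of the assay and not a number. Compound 2 `C=C1[C@H](n2cnc3c(Cl)nc(N)nc32)O[C@H](CO)[C@H]1O` gives a true number, 176000 nM. Going by these compounds, compound 3 `C=C1[C@H](n2cnc3c(N)nc(N)nc32)O[C@H](CO)[C@H]1O` reads > 500000 nM, again only a limit, so its real value is unknown and any step starting from it is uncertain.

Compound 4 `C=C1[C@H](n2cnc3c(O)nc(N)nc32)O[C@H](CO)[C@H]1O` differs from compound 3 by one change, hydroxy in place of amino on an aromatic carbon. Among the measured compounds shown here, the only measured step that bears on this concerns the same carbon, where amino in place of chloro gave an at least 2.8-fold higher number from compound 2 to compound 3 (0.45 log units; beyond the scatter). For the measured compounds named here, no measured step covers hydroxy itself, and the data are thin: the limit of > 500000 nM in this assay, at which 2 of the 3 values shown sit.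

Losing the amino group that came with that weaker reading may win back a little, so a modest move towards a lower number is expected in this assay, though another limit reading is quite possible. The expected change is an at least 1.6-fold lower number from compound 3 to compound 4 (0.22 log units; that floor lies within the scatter). For compound 4 the estimated value is 300000 nM, with an expected range of 80000 nM to 500000 nM.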

Compound 4, half-maximal inhibitory concentration: 150000 nM
Beside the measured number, compound 4's estimate is 2.0-fold (0.30 log units) above it; the range from low to high includes it.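

In this assay, this aromatic carbon now has three groups to compare, and the choice of group matters: hydroxy in place of amino gives an at least 3.3-fold lower number from compound 3 to compound 4 (0.52 log units; beyond the scatter). Hydroxy in place of chloro gives a 1.2-fold lower number from compound 2 to compound 4 (0.07 log units; within the scatter), so these two groups cannot be told apart here, and amino is the only one of the three whose steps to the others lie beyond the scatter. Compound 3 reads only as a limit, so the step away from it has a floor but no true size: the limit of > 500000 nM in this assay, at which 2 of the 4 values shown sit.

Going by these compounds, it remains open whether a methoxy group, a thiol or a methylamino group at this carbon would read like hydroxy and chloro or like amino. Also open, on these data alone, is how far below these readings a group on the shared core would have to go to give a clearly stronger inhibitor.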